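The compounds below may be only part of what the source reports. "The series", "measured", "known", "first", "only" and "open" are said of these compounds alone.

Measured in a functional assay on CCRF-CEM cells (Homo sapiens); a higher number here means that more compound is needed for the effect, a lower number that less compound is needed:
- compound 1 `Nc1ncn(C[C@H]2CO[C@H](CO)O2)c(=O)n1`: 30000 nM
- compound 2 `Cc1nn(C[C@@H]2CO[C@H](CO)O2)c(=O)[nH]c1=O`: > 100000 nM

Compound 2 gives no number, only a limit of the assay, > 100000 nM. Compound 3 `Cc1nn(C[C@H]2CO[C@@H](CO)O2)c(=O)[nH]c1=O` is built from the same parts: the two compounds have the same atoms and bonds and differ only in configuration as drawn: 2 of 2 stereo elements differ (all stereocentres are inverted: mirror images); a stereocentre at a saturated ring carbon is drawn R in compound 2 and S in compound 3; a stereocentre at a saturated ring carbon is drawn S in compound 2 and R in compound 3. Among the measured compounds shown here, no measured pair shows what such an inversion does here, so any forecast is uncertain. In this assay compound 1 needs 30000 nM, and this sole numerical value is itself large. No step beyond the scatter is therefore expected, though a shift towards less compound needed remains possible. The expected step of a number no higher from compound 2 to compound 3 (the limit leaves the size open) is small. Compound 3 is estimated at 100000 nM, with an expected range of 25000 nM to 300000 nM.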

Compound 3, half-maximal effective concentration: > 100000 nM
Compound 3: a limit, no number; the forecaster's own chance of this, stated with the estimate: 70%; the middle value sits exactly at the limit.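

Compound 3 gives > 100000 nM in this assay, which is a limit of the assay and not a number. Compound 2 sits at the same limit, and the step between the two cannot be read. Going by these compounds, whether inverting both stereocentres changes the effect at all stays open.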